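Chloro in place of nitro on the aromatic ring

This account rests on a few compounds, and the source may have more. Where it says the series, first, only, none or still open, it means among the compounds named here.

Within the data shown here, in a functional assay on A-431 cells (Homo sapiens) for antiproliferative activity, read by CCK-8 assay, with a stated time of 72 h (on this read-out lower numbers stand for stronger inhibition and higher numbers for weaker inhibition), compound 2 `Cc1cc(Nc2cc(N3CCN(C)CC3)nc(Nc3ccc([N+](=O)[O-])cc3)n2)n[nH]1` gives 150 nM, the lower of the two numbers measured so far. Compound 1 `Cc1cc(Nc2cc(N3CCN(C)CC3)nc(Nc3ccc(S(N)(=O)=O)cc3)n2)n[nH]1` reads 2760 nM, and that gap lies beyond the scatter. Compound 3 `Cc1cc(Nc2cc(N3CCN(C)CC3)nc(Nc3ccc(Cl)cc3)n2)n[nH]1` has no number yet in this assay. Its difference from compound 2 is chloro in place of nitro on an aromatic carbon, para to a large group. Among the measured compounds shown here, only one measured step bears on this, at the same place: an 18-fold lower number from compound 1 to compound 2 (1.26 log units; beyond the scatter), a large step, with nitro in place of sulfamoyl. For the measured compounds named here, it shows that the number can move strongly with the group at this place, but no measured compound carries chloro, so it fixes no direction for this swap. A modest move toward a higher number is expected, possibly within the scatter. The expected step is a 1.5-fold higher number from compound 2 to compound 3 (0.17 log units; within the scatter). For compound 3 the estimate is 220 nM, with an expected range from 70 nM to 700 nM.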

Compound 3, half-maximal inhibitory concentration: 162 nM
Compound 3: the middle estimate sits 1.4-fold (0.13 log units) above what was measured, and the stated range covers the measured number.
By their numbers in this assay, from the lowest: compounds 2 and 3 (each within the scatter of the next); then compound 1.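

In this assay, a 1.1-fold higher number from compound 2 to compound 3 (0.03 log units; within the scatter) places chloro and nitro within the scatter of each other, so on this aromatic carbon, para to a large group, a single chlorine atom gives the same reading as the three heavy atoms of nitro, and the hydrogen-bond acceptors of nitro are not required for it. Sulfamoyl now stands apart from two groups rather than one: a 17-fold lower number from compound 1 to compound 3 (1.23 log units; beyond the scatter), a step much like the earlier one with nitro, so that large gap was not particular to nitro. Nothing measured here accounts for why sulfamoyl differs from the other two groups.

The compounds shown leave open whether an amine, a carboxylic acid or a methyl group at this place would read like chloro and nitro or like sulfamoyl. They also leave open what a bare hydrogen there would give.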